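From 4-fluorobenzyl to 4-chlorobenzyl: notes on the series

The source may hold more compounds than are shown below. What is called first, only, known or untested is meant among the compounds shown, and "the series" means these compounds.

Three related compounds have been measured so far: compound 1 `CCOC(=O)N1[C@@H]2C=C[C@@](OC)(C(=O)c3c2cc(OC)c(OC)c3OCC)N1C(=O)OCC`, compound 2 `COC(=O)N1[C@@H]2C=C[C@@](OC)(C(=O)c3c2cc(OC)c(OC)c3OCc2ccc(F)cc2)N1C(=O)OC` and compound 3 `CCCOc1c(OC)c(OC)cc2c1C(=O)[C@]1(OC)C=C[C@H]2N(C(=O)OCC)N1C(=O)OCC`. For the measured compounds named here, in an ADME assay on KB cells (Homo sapiens) for cytotoxicity (on this read-out higher numbers stand for an effect only at larger amounts of compound and lower numbers for an effect already at smaller amounts), compound 2 gives 56.6 ug/mL, the only actual number among the three. Compound 1 reads > 300 ug/mL, which is a limit of the assay. Compound 3 reads > 300 ug/mL, which is also a limit. Both of these compounds sit at the limit of > 300 ug/mL in this assay, at which 2 of the 3 values shown sit.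

The next compound, compound 4 `COC(=O)N1[C@@H]2C=C[C@@](OC)(C(=O)c3c2cc(OC)c(OC)c3OCc2ccc(Cl)cc2)N1C(=O)OC`, departs from compound 2 in one place: chloro in place of fluoro on an aromatic carbon. This is chloro in place of fluoro on an aromatic carbon, para to a large group, turning 4-fluorobenzyl into 4-chlorobenzyl.

Going by the values given here, the only measured single-place step is a step that the two limits leave unreadable from compound 1 to compound 3, with methyl in place of hydrogen on a saturated chain carbon. It is a different change and offers no size to carry over. Among the compounds with values here, no measured step exchanges one halogen for another. The expectation therefore rests on compound 2 alone, at 56.6 ug/mL, and the range is kept wide.

No shift beyond the scatter is expected in this assay. The expected change is a 1.1-fold lower number from compound 2 to compound 4 (0.05 log units; within the scatter). For compound 4 the estimate is 50 ug/mL, with an expected range of 20 ug/mL to 150 ug/mL.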

Compound 4, concentration for half-maximal effect: 55.9 ug/mL
Compound 4: middle estimate off by 1.1-fold (0.05 log units), on the low side, within the range that was stated.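

In this assay, chloro in place of fluoro on an aromatic carbon, para to a large group, gives a 1.0-fold lower number from compound 2 to compound 4 (0.01 log units; within the scatter). For the compounds shown here, this is the first readable step and the first exchange of one halogen for another, and at this position on the benzyl group the two halogens stand in for each other with no shift beyond the scatter. Compound 2 and compound 4 both give numbers, so their step has a size, while the only earlier step between measured compounds cannot be read, with both of its compounds sitting at a limit: the limit of > 300 ug/mL in this assay, at which 2 of the 4 values shown sit.

Still open, from the compounds shown here alone, is whether the same flat read-out holds at this position for groups other than these two halogens, such as bromo, methoxy, trifluoromethyl, a nitrile or an amine. Also open, going by these compounds, is what the 4-chlorobenzyl group contributes by itself, since compound 4 differs from compound 1 in more than one place, and a single-place comparison would need a (4-chlorobenzyl)oxy group on the core with ethyl carbamates.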